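This account rests on a few compounds, and the source may have more. Where it says the series, first, only, none or still open, it means among the compounds named here.

Compound 3 `O=C1O[C@H]([C@@H](O)Cn2cc(CCCCl)nn2)C(OCc2ccccc2)=C1OCc1ccccc1` gives 29000 nM in a functional assay on A549 cells (Homo sapiens) for antiproliferative activity, read by MTT assay, with a stated time of 72 h (on this read-out higher numbers stand for weaker inhibition and lower numbers for stronger inhibition), the second highest of the three numbers now in hand. Compound 2 `O=C1O[C@H]([C@@H](O)Cn2cc(-c3cc(F)cc(F)c3)nn2)C(OCc2ccccc2)=C1OCc1ccccc1` gives 41200 nM, and the gap between the two is a 1.4-fold lower number from compound 2 to compound 3 (0.15 log units; within the scatter). Compound 1 `CCCCCc1ccc(-c2cn(C[C@H](O)[C@H]3OC(=O)C(OCc4ccccc4)=C3OCc3ccccc3)nn2)cc1` gives 6220 nM; from it the step to compound 3 was a 4.7-fold higher number from compound 1 to compound 3 (0.67 log units; beyond the scatter) and the step to compound 2 was a 6.6-fold higher number from compound 1 to compound 2 (0.82 log units; beyond the scatter). Compound 4 `Cc1ccc(S(=O)(=O)NCc2cn(C[C@H](O)[C@H]3OC(=O)C(OCc4ccccc4)=C3OCc3ccccc3)nn2)cc1` carries ((4-methylphenyl)sulfonyl)amino in place of 2-chloroethyl on a saturated chain carbon bound to an aromatic carbon. The measured steps all exchange the group on the aromatic carbon of the shared core, none of them involves a sulfonamide, and only compound 1 shows a step beyond the scatter. The change to compound 4 brings in an aromatic ring again, but attached in a way not covered by any measured step, so in this assay a step within the scatter, possibly toward a somewhat lower number, is the most defensible expectation. The expected step is a 1.5-fold lower number from compound 3 to compound 4 (0.16 log units; within the scatter). Compound 4 is therefore estimated at 20000 nM, with a range from 6000 nM to 60000 nM.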

Compound 4, half-maximal inhibitory concentration: 16800 nM
Compound 4: the middle estimate sits 1.2-fold (0.08 log units) above what was measured; the measured number falls inside the stated range.
By their numbers in this assay, from the lowest: compound 1; then compounds 4, 3 and 2 (each within the scatter of the next, the first and the last beyond it).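

Replacing 2-chloroethyl with ((4-methylphenyl)sulfonyl)amino on a saturated chain carbon bound to an aromatic carbon brings in an aromatic ring, a hydrogen-bond donor and hydrogen-bond acceptors, yet the number in this assay stays within the scatter (a 1.7-fold lower number from compound 3 to compound 4 (0.24 log units; within the scatter)). Cut one bond further out, the same group separates from both aryl groups on the aromatic carbon, with the gap to 3,5-difluorophenyl (a 2.5-fold lower number from compound 2 to compound 4 (0.39 log units; beyond the scatter)) pointing the opposite way from the gap to 4-pentylphenyl (a 2.7-fold higher number from compound 1 to compound 4 (0.43 log units; beyond the scatter)), so compound 1 remains the most potent of the four. No measurement shown accounts for these differences.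

As far as these compounds go, a primary amine or a carboxylic acid on the same saturated chain carbon remains open. So does whether a longer alkyl chain without the phenyl ring would match the number of compound 1.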